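Adding an Isobutyl Group to a Sulfonamide Piperidine Core

This account rests on a few compounds, and the source may have more. Where it says the series, first, only, none or still open, it means among the compounds named here.

The compounds here were tested in a functional assay on A2780 cells (Homo sapiens) for antiproliferative activity, read by sulforhodamine B assay, with a stated time of 48 h; on this read-out lower numbers stand for stronger inhibition of growth and higher numbers for weaker inhibition of growth. Compound 1, with the structure `Cc1ccc(S(=O)(=O)N2CCC(Cl)CC2)cc1`, is the plain core. In this assay compound 1 gives only a limit, > 100000 nM, and not a number. Compound 2, with the structure `Cc1ccc(S(=O)(=O)N2CC[C@@H](Cl)C[C@@H]2CC(C)C)cc1`, carries an added group on the core; in this assay compound 2 gives 36000 nM. The step between them is an at least 2.7-fold lower number from compound 1 to compound 2 (0.44 log units; beyond the scatter), and the change behind it is isobutyl in place of hydrogen on a saturated ring carbon. That step is a lower bound rather than an exact size because of the limit of > 100000 nM in this assay, at which 2 of the 3 values shown sit, so the true gain may be larger than the number shows.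

Compound 3, with the structure `Cc1ccc(S(=O)(=O)N2CC=C(Br)CC2)cc1`, has a different core. In this assay compound 3 also gives only a limit, > 100000 nM. How the core of compound 3 differs from the core of compound 1 is not broken down here.

Compound 4, with the structure `Cc1ccc(S(=O)(=O)N2CCC(Br)=CC2CC(C)C)cc1`, has not yet been measured. It stands to compound 3 as compound 2 stands to compound 1: the change is isobutyl in place of hydrogen on a saturated ring carbon. The surroundings are not identical, since the ring atom two ring bonds away bears a bromo group rather than a chloro group, so this is the same kind of change rather than the same change. Going by the values given here, on the single measured step, the expected step is an at least 2.0-fold lower number from compound 3 to compound 4 (0.30 log units; that floor lies within the scatter), resting on an at least 2.7-fold lower number from compound 1 to compound 2 (0.44 log units; beyond the scatter) between compound 1 and compound 2. The value for compound 4 is estimated at 50000 nM, expected to lie between 15000 nM and 120000 nM.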

Compound 4, concentration for 50% growth inhibition: 36000 nM
Estimate against measurement, compound 4: 1.4-fold (0.14 log units) above; the range from low to high includes it.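

In this assay, isobutyl in place of hydrogen on a saturated ring carbon again goes with stronger inhibition of growth, with an at least 2.7-fold lower number from compound 3 to compound 4 (0.44 log units; beyond the scatter), so the direction of the change holds on both cores shown: the same change on two cores in this assay, an at least 2.7-fold lower number (0.44 log units; beyond the scatter) from compound 1 to compound 2 and an at least 2.7-fold lower number (0.44 log units; beyond the scatter) from compound 3 to compound 4; the limit leaves it open whether they differ. The true size of each step stays hidden because each parent compound gives a limit and not a number: the limit of > 100000 nM in this assay, at which 2 of the 4 values shown sit. The two steps therefore show that the change carries over in direction from the core of compound 1 to the core of compound 3, but they do not show how large the gain is on either core, or whether one core gains more than the other.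

The compounds shown leave open whether the gain is specific to isobutyl, which a methyl group, a longer chain or an amine at the same ring carbon would help to settle. They also leave open whether the change would carry over to a core with another group, such as a nitrile, in place of the chloro or bromo group.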